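The source may hold more compounds than are shown below. What is called first, only, known or untested is meant among the compounds shown, and "the series" means these compounds.

Measured in a functional assay on L1210 cells (Mus musculus) for antiproliferative activity, read by MTT assay, with a stated time of 72 h (on this read-out higher numbers stand for weaker inhibition and lower numbers for stronger inhibition), so far:
Compound 1 `COc1cc(C2=NN(C(C)=O)C(c3ccc([N+](=O)[O-])cc3)O2)cc(OC)c1OC` gives 4200 nM
Compound 2 `COc1cc(OC)cc(C2OC(c3cc(OC)c(OC)c(OC)c3)=NN2C(C)=O)c1` gives 5900 nM

Compound 1 and compound 2 stand within the scatter of each other. Compound 3 `COc1cc(C2=NN(C(C)=O)C(c3cccc(Br)c3)O2)cc(OC)c1OC` awaits measurement and differs from compound 1 by 3-bromophenyl in place of 4-nitrophenyl on a saturated ring carbon with 3-bromophenyl in place of 4-nitrophenyl on a saturated ring carbon. Going by the values given here, one measured step bears on this, a 1.4-fold higher number from compound 1 to compound 2 (0.15 log units; within the scatter) and it shows an exchange at that carbon staying within the scatter. No step beyond the scatter is therefore expected in this assay and the expected change is a 1.1-fold lower number from compound 1 to compound 3 (0.02 log units; within the scatter) in size. For compound 3 the estimated value is 4000 nM with 1300 nM to 12000 nM as its expected range.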

Compound 3, half-maximal inhibitory concentration: 600 nM
Compound 3: the middle estimate sits 6.7-fold (0.82 log units) above what was measured; measured number outside the range, below it.
By their numbers in this assay, from the lowest: compound 3; then compounds 1 and 2 (each within the scatter of the next).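

In this assay, going by these compounds alone, the group on the saturated ring carbon proves able to shift the read-out: 3-bromophenyl in place of 4-nitrophenyl gives a 7.0-fold lower number from compound 1 to compound 3 (0.85 log units; beyond the scatter) and in place of 3,5-dimethoxyphenyl gives a 9.8-fold lower number from compound 2 to compound 3 (0.99 log units; beyond the scatter) whereas the one earlier exchange at this carbon stayed within the scatter. Compound 3 therefore stands lowest of the three. Nothing available explains why this exchange lowers the number. The compounds shown leave open whether chlorine or an amine on that phenyl ring would do the same. From the compounds shown here alone, whether the place of the bromine on the ring matters also remains open.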